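Pentyl to benzyl on the aromatic nitrogen

The compounds below may be only part of what the source reports. "The series", "measured", "known", "first", "only" and "open" are said of these compounds alone.

Values in a functional assay on HCT-15 cells (Homo sapiens) for antiproliferative activity, read by MTT assay, with a stated time of 72 h; a lower number here means a stronger inhibitor, a higher number a weaker inhibitor:
compound 1 `COc1cc(-c2nccn2C(C)C)cc(OC)c1OC` gives > 100000 nM (a limit)
compound 2 `CCCCCn1ccnc1-c1cc(OC)c(OC)c(OC)c1` gives > 100000 nM (a limit)

Compound 2 stands only at a limit (> 100000 nM). Within the data shown here, the series so far shows the limit of > 100000 nM in this assay, at which 2 of the 2 values shown sit, and no number. Compound 3 `COc1cc(-c2nccn2Cc2ccccc2)cc(OC)c1OC` is reached by phenyl in place of butyl on a saturated chain carbon bound to an aromatic nitrogen (the same difference reads pentyl to benzyl). Among the measured compounds shown here, the one measured step (a step that the two limits leave unreadable from compound 1 to compound 2) bears on this change, but its size cannot be read. No step beyond the scatter is therefore expected in this assay and no direction can be favoured. The estimated step (a number no higher from compound 2 to compound 3 (the limit leaves the size open)) is expected to be small. For compound 3 the estimated value is 100000 nM (expected range 30000 nM to 200000 nM).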

Compound 3, half-maximal inhibitory concentration: > 100000 nM
Compound 3: a limit, no number (the forecaster's own chance of this, stated with the estimate: 70%); the middle value lies on the limit itself.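

No step can be read among compound 1, compound 2 and compound 3, whose results are all limits and not numbers: the limit of > 100000 nM in this assay, at which 3 of the 3 values shown sit.

The compounds shown leave open whether any group on the aromatic nitrogen of the shared core gives a measurable value.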